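Bicyclic amine in place of cyclopropylpiperidine at the ring nitrogen

The source may report more compounds than this note shows. Statements on the series, on what has been measured and on what is new or still open speak of the compounds shown alone.

compound 1 `COc1cc(C)c(S(=O)(=O)N(C)CCOCC(=O)N2CCC(C3CCN(C)CC3)CC2)c(C)c1` — in a functional assay on Umbilical vein for antagonist activity at B1 bradykinin receptor (Homo sapiens), using Schild analysis, with a stated time of 30 min (a higher number here means a more potent compound, by a factor of ten per unit of this negative logarithm, a lower number a less potent compound), compound 1 gives 9
compound 2 `COc1cc(C)c(S(=O)(=O)N(C)CCOCC(=O)N2CCN(C3CCN(C4CC4)CC3)CC2)c(C)c1` — in this assay compound 2 gives 8.5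
compound 3 `CN(Cc1ccc(C2=NCCN2)cc1)C(=O)COCCN(C)S(=O)(=O)c1c(F)cccc1F` — in this assay compound 3 gives 7.6

Compound 2 holds the second highest of the three numbers: compound 1 stands above it by a gap beyond the scatter, and compound 3 lies further below, also beyond the scatter. Compound 4 `COc1cc(C)c(S(=O)(=O)N(C)CCOCC(=O)N2CCN([C@H]3CN4CCC3CC4)CC2)c(C)c1` differs from compound 2 in one place: a group of 8 heavy atoms (7 carbon, 1 nitrogen; 2 six-membered non-aromatic rings with 1 hetero atom each) in place of a group of 9 heavy atoms (8 carbon, 1 nitrogen; one three-membered non-aromatic ring of carbon only, one six-membered non-aromatic ring with 1 hetero atom), on an amine nitrogen in a ring. Within the data shown here, no measured pair differing in one place is at hand, so the size of this step cannot be read from a measured step. The expected step is a number 0.20 log units lower from compound 2 to compound 4 (within the scatter), a small fall or none beyond the scatter. Compound 4 is expected to give 8.3 in this assay, between 7.5 and 9.1, because compound 2 gives 8.5 and the change keeps a basic amine in a ring at the same place.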

Compound 4, negative logarithm of the antagonist equilibrium constant: 7.2
Beside the measured number, compound 4's estimate is 1.10 log units above it; the whole stated range lies above it.
By their numbers in this assay, from the lowest: compound 4; then compound 3; then compound 2; then compound 1.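

In this assay, the group with two six-membered rings in place of 1-cyclopropylpiperidin-4-yl on the ring amine nitrogen gives a large fall, a number 1.30 log units lower from compound 2 to compound 4 (beyond the scatter). The two groups match in their counts of hydrogen-bond donors and acceptors and each holds a ring nitrogen, yet this position clearly tells them apart. Nothing at hand accounts for the size of this step. As far as these compounds go, whether a 1-isopropylpiperidin-4-yl group on the same nitrogen would keep the number of compound 2 remains open, as does how the opposite stereoisomer of the entering group would fare.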